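Swapping one group on compound 3

The source may hold more compounds than are shown below. What is called first, only, known or untested is meant among the compounds shown, and "the series" means these compounds.

Compound 1 `Nc1nc(Nc2ccc(N3CCN(C4CC5CCC4C5)CC3)cc2)nn1-c1nccc2ccccc12` gives 2.3 h
Compound 2 `COc1cc2ncnc(-n3nc(Nc4ccc(N5CCN(C6CC7CCC6C7)CC5)c(Cl)c4)nc3N)c2cc1OC` gives 2.7 h
Compound 3 `Cc1csc2c(-n3nc(Nc4ccc(N5CCN(C6CC7CCC6C7)CC5)cc4)nc3N)nc(Cl)nc12` gives 4.9 h

All three numbers come from an ADME assay on the whole organism (strain Sprague-Dawley) for metabolic stability, with Rattus norvegicus as the target (on this read-out lower numbers stand for a shorter-lived compound and higher numbers for a longer-lived compound), and can be compared directly. Compound 2 and compound 3 lie within the usual scatter of each other, so those two cannot be told apart. Within the data shown here, the only measured step that changes a single place is a 2.1-fold higher number from compound 1 to compound 3 (0.33 log units; beyond the scatter), which is modest but beyond the scatter. It exchanges the group on an aromatic nitrogen.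

Compound 4 `Nc1nc(Nc2ccc(N3CCN(C4CC5CCC4C5)CC3)cc2)nn1-c1ncnc2ccc(F)cc12` has not been measured, and the same place changes again: a group of 11 heavy atoms (8 carbon, 2 nitrogen, 1 fluorine; one six-membered aromatic ring of carbon only, one six-membered aromatic ring with 2 hetero atoms) in place of a group of 11 heavy atoms (7 carbon, 2 nitrogen, 1 sulfur, 1 chlorine; one five-membered aromatic ring with 1 hetero atom, one six-membered aromatic ring with 2 hetero atoms), on an aromatic nitrogen. The entering 6-fluoroquinazolin-4-yl group has a six-membered aromatic ring of carbon only, as the group in compound 1 does, and the leaving group lacks one. Part of the measured step of a 2.1-fold higher number from compound 1 to compound 3 (0.33 log units; beyond the scatter) is therefore expected to reverse. Among the measured compounds shown here, this is a cautious expectation, since it rests on one step, and no measured compound isolates the fluorine. The expected direction is towards a lower number, with an estimated step of a 1.8-fold lower number from compound 3 to compound 4 (0.24 log units; within the scatter) in this assay on this reasoning. Compound 4 is expected at about 2.8 h, with an estimated range from 1.4 h to 5.5 h.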

Compound 4, half-life: 2.3 h
Compound 4: the middle estimate sits 1.2-fold (0.09 log units) above what was measured; the range from low to high includes it.
By their numbers in this assay, from the lowest: compounds 1, 4, 2 and 3 (each within the scatter of the next, the first and the last beyond it).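

In this assay, the step of a 2.1-fold lower number from compound 3 to compound 4 (0.33 log units; beyond the scatter) lies beyond the scatter, so compound 3 now stands apart from two other groups at this aromatic nitrogen, not only from the group in compound 1. The two groups that carry a six-membered aromatic ring of carbon only, isoquinolin-1-yl and 6-fluoroquinazolin-4-yl, cannot be told apart, with no change at the digits printed from compound 1 to compound 4 (within the scatter) within the scatter, so among compounds 1, 3 and 4 the higher number belongs to compound 3 alone, and adding a second hetero atom to the six-membered ring together with a fluorine leaves the number where it was. No measured property of these groups is available to explain this pattern.

From the compounds shown here alone, the group in compound 3 differs from the other two in several features at once, including its sulfur, its chlorine and its five-membered aromatic ring, so which of these goes with the higher number stays open. Going by these compounds, it is also open whether a nitrile in place of the fluorine, or a single-ring phenyl on this aromatic nitrogen, would move the half-life at all.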